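The compounds below may be only part of what the source reports. "The series", "measured", "known", "first", "only" and "open" are said of these compounds alone.

Compound 1 `N#C/C(=C\c1ccccc1OS(=O)(=O)c1ccc([N+](=O)[O-])cc1)C(=O)Nc1nnc(Cc2ccccc2)s1` is the starting point of this small series. In a functional assay on HL-60 cells (Homo sapiens) for inhibition, read by CCK-8 assay, with a stated time of 48 h, tested at 20 uM (a higher number here means more inhibition of growth at the concentration tested, a lower number less inhibition of growth), compound 1 gives 20%. Compound 2 `N#C/C(=C\c1ccccc1OS(=O)(=O)c1ccccc1[N+](=O)[O-])C(=O)Nc1nnc(Cc2ccccc2)s1` keeps the same core but differs from compound 1 by 2-nitrophenyl in place of 4-nitrophenyl on a sulfonyl sulfur. In this assay compound 2 gives 12%, and the step of a number 8 percentage points lower from compound 1 to compound 2 (within the scatter) is one that the usual scatter of repeated measurements could account for on its own. Compound 3 `N#C/C(=C\c1ccccc1OS(=O)(=O)c1ccc([N+](=O)[O-])cc1)C(=O)Nc1nnc(Cc2ccc(Cl)cc2)s1` carries a different core, differing from compound 1 by chloro in place of hydrogen on an aromatic carbon. In this assay compound 3 gives 34%, the highest of the three measured numbers, and the step of a number 14 percentage points higher from compound 1 to compound 3 (beyond the scatter) lies beyond the scatter.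

Compound 4 `N#C/C(=C\c1ccccc1OS(=O)(=O)c1ccccc1[N+](=O)[O-])C(=O)Nc1nnc(Cc2ccc(Cl)cc2)s1` has not been measured. It differs from compound 3 by 2-nitrophenyl in place of 4-nitrophenyl on a sulfonyl sulfur, the same change that separates compound 1 from compound 2, and it shares the core of compound 3 rather than that of compound 1. Among the measured compounds shown here, the only guide to what that change does is the single earlier step of a number 8 percentage points lower from compound 1 to compound 2 (within the scatter), which was small. The step of a number 7 percentage points lower from compound 3 to compound 4 (within the scatter) is therefore expected to be of a similar small size, resting on the earlier pair alone. For compound 4 the expected value in this assay is 27%, with a range estimated from 14% to 40%, because the reference step a number 8 percentage points lower from compound 1 to compound 2 (within the scatter) stayed within the scatter.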

Compound 4, percent growth inhibition at one concentration: 19%
For compound 4 the middle estimate is 8 percentage points above the measured one; measured number inside the range.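

In this assay, 2-nitrophenyl in place of 4-nitrophenyl on the sulfonyl sulfur gives a number 15 percentage points lower from compound 3 to compound 4 (beyond the scatter), and this step does not differ from the earlier one on the core of compound 1 by more than the scatter allows: the same change on two cores in this assay, a number 8 percentage points lower (within the scatter) from compound 1 to compound 2 and a number 15 percentage points lower (beyond the scatter) from compound 3 to compound 4, 7 percentage points apart, within the scatter of two such steps. The chloro change gives a number 7 percentage points higher from compound 2 to compound 4 (within the scatter), and it too stays in line with its earlier counterpart: the same change on two cores in this assay, a number 14 percentage points higher (beyond the scatter) from compound 1 to compound 3 and a number 7 percentage points higher (within the scatter) from compound 2 to compound 4, 7 percentage points apart, within the scatter of two such steps. Among the compounds shown here, these four compounds therefore give no sign that either change behaves differently on the two cores, but each comparison rests on only two steps, one of which stays within the scatter, so they fix no size for either change and say nothing about any other core.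

The compounds shown leave open what an amine or a carboxylic acid would do in place of the nitro group on the sulfonyl-bound ring. They also leave open whether a bromine or a methoxy group in place of the chloro would give a number in this assay like that of the chloro compounds.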